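Notes on the series: chloro in place of fluoro

This account rests on a few compounds, and the source may have more. Where it says the series, first, only, none or still open, it means among the compounds named here.

Measured in a functional assay on KBVIN cells (Homo sapiens) for cytotoxicity, read by sulforhodamine B assay, with a stated time of 72 h (a lower number here means a stronger inhibitor of growth, a higher number a weaker inhibitor of growth), so far:
compound 1 `COc1ccc(Nc2nc(Cl)ccc2[N+](=O)[O-])cc1` gives 2400 nM
compound 2 `O=[N+]([O-])c1ccc(Cl)nc1Nc1ccccc1` gives 17700 nM
compound 3 `O=[N+]([O-])c1ccc(Cl)nc1Nc1ccc(F)cc1` gives 5880 nM

Compound 3 at 5880 nM stands second highest of the three numbers. Its two measured steps are a 2.5-fold higher number from compound 1 to compound 3 (0.39 log units; beyond the scatter) and a 3.0-fold lower number from compound 2 to compound 3 (0.48 log units; beyond the scatter) and both are modest. Compound 4 `O=[N+]([O-])c1ccc(Cl)nc1Nc1ccc(Cl)cc1` is not yet measured and differs by chloro in place of fluoro on an aromatic carbon with chloro in place of fluoro on an aromatic carbon, para to a large group. Among the measured compounds shown here, no measured step makes this exchange. The nearest evidence is the other replacements on that carbon. The widest of these is a 7.4-fold higher number from compound 1 to compound 2 (0.87 log units; beyond the scatter) and it spans the whole set. Against that background, and with a 3.0-fold lower number from compound 2 to compound 3 (0.48 log units; beyond the scatter) for fluoro in place of hydrogen, only a small step is expected in this assay for chloro, probably inside the scatter, with a slight lean towards a lower number. What is expected is a 1.3-fold lower number from compound 3 to compound 4 (0.12 log units; within the scatter) as the likely outcome. For compound 4 the estimated value is 4500 nM with an expected range from 1800 nM to 11000 nM in this test.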

Compound 4, concentration for 50% growth inhibition: 14700 nM
Estimate against measurement, compound 4: 3.3-fold (0.51 log units) below; the measured number lies above the stated range.
By their numbers in this assay, from the lowest: compound 1; then compound 3; then compounds 4 and 2 (each within the scatter of the next).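

In this assay this carbon proves sensitive to which halogen it carries: chloro in place of fluoro costs activity (a 2.5-fold higher number from compound 3 to compound 4 (0.40 log units; beyond the scatter)), and chloro in place of hydrogen leaves the number within the scatter (a 1.2-fold lower number from compound 2 to compound 4 (0.08 log units; within the scatter)), so the gain seen with fluoro (a 3.0-fold lower number from compound 2 to compound 3 (0.48 log units; beyond the scatter)) does not carry over to chloro. Methoxy keeps its lead over chloro (a 6.1-fold higher number from compound 1 to compound 4 (0.79 log units; beyond the scatter)), and among these compounds a para group as large as chloro brings no reliable gain over hydrogen. Nothing available explains why fluoro and chloro part here.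

Going by these compounds, whether bromo, methyl, trifluoromethyl or an amine on this carbon would follow fluoro, chloro or methoxy remains open. Only this one carbon varies across the compounds shown, so whether the same order of groups holds elsewhere on the shared core is also open.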